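Replacing 4-ethylphenyl with thiophen-2-yl

A few compounds are considered here, and "the series" means these few. Any claim that something is new, unique, unknown or untested is made for them only; others in the source may bear on it.

Compound 1 (`COC1=C(C)C(=O)/C(=C(O)/C=C/c2ccc(Br)cc2)C(=O)C1(C)C`): 17.7 ug/mL
Compound 2 (`CCc1ccc(/C=C/C(O)=C2/C(=O)C(C)=C(OC)C(C)(C)C2=O)cc1`): 15.1 ug/mL

In a functional assay on PC-3 cells (Homo sapiens) for cytotoxicity (on this read-out lower numbers stand for an effect already at smaller amounts and higher numbers for an effect only at larger amounts of compound), compound 2, at 15.1 ug/mL, stands level with compound 1, at 17.7 ug/mL. Compound 3 (`COC1=C(C)C(=O)/C(=C(O)/C=C/c2cccs2)C(=O)C1(C)C`) follows from compound 2 by one change: thiophen-2-yl in place of 4-ethylphenyl on a double-bonded chain carbon bound to a double-bonded chain carbon. For the measured compounds named here, only one measured step bears on this, and only loosely: a 1.2-fold lower number from compound 1 to compound 2 (0.07 log units; within the scatter), with ethyl in place of bromo on an aromatic carbon. Going by the values given here, no measured pair exchanges one ring for another, so no step beyond the scatter is expected in this assay. The expected step is a 1.1-fold higher number from compound 2 to compound 3 (0.05 log units; within the scatter). For compound 3 the estimated value is 17 ug/mL, with an expected range of 8 ug/mL to 36 ug/mL.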

Compound 3, concentration for half-maximal effect: 18.2 ug/mL
Compound 3: the middle estimate sits 1.1-fold (0.03 log units) below what was measured; the measured number falls inside the stated range.
By their numbers in this assay, from the lowest: compounds 2, 1 and 3 (each within the scatter of the next).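

In this assay the six-membered aromatic ring on this double-bonded chain carbon gives way to a five-membered aromatic ring holding sulfur with no step beyond the scatter, with a 1.2-fold higher number from compound 2 to compound 3 (0.08 log units; within the scatter) and a 1.0-fold higher number from compound 1 to compound 3 (0.01 log units; within the scatter) as the two readings. The earlier step changed only a group on the six-membered ring, whereas here the ring itself changes and the number stays level, even with fewer heavy atoms in thiophen-2-yl than in 4-ethylphenyl. Nothing available explains why the values stay level.

Going by these compounds, whether an amine or a carboxylic acid on the ring would move the number beyond the scatter stays open. So does the effect of a longer chain in place of the ring at this position.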